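This account rests on a few compounds, and the source may have more. Where it says the series, first, only, none or still open, it means among the compounds named here.

Three analogues built on a shared core were examined in a toxicity assay on EA.hy 926 cells (Homo sapiens) for cytotoxicity, read by MTT assay, with a stated time of 48 h; on this read-out higher numbers stand for weaker inhibition and lower numbers for stronger inhibition. Compound 1 `COc1cc(/C=C/C(=O)/C=C(/C=C/c2ccc(O)c(OC)c2)NCCO)ccc1O` gives > 100000 nM in this assay, a limit of the assay rather than a number. Compound 2 `COc1cc(/C=C/C(=O)/C=C(/C=C/c2ccc(O)c(OC)c2)NCCCO)ccc1O` likewise gives > 100000 nM in this assay, again a limit. Compound 3 `COCCNC(=C\C(=O)/C=C/c1ccc(O)c(OC)c1)/C=C/c1ccc(O)c(OC)c1` stands at >= 100000 nM in this assay, also a limit. Because the limit of > 100000 nM in this assay, at which 2 of the 3 values shown sit, and the limit of >= 100000 nM in this assay, at which 1 of the 3 values shown sits, bound every value shown, the steps a step that the two limits leave unreadable from compound 1 to compound 2, a step that the two limits leave unreadable from compound 1 to compound 3 and a step that the two limits leave unreadable from compound 2 to compound 3 cannot be sized; compound 3 therefore sits with the other two at the edge of what this assay can read. Compound 4 `COCCCNC(=C\C(=O)/C=C/c1ccc(O)c(OC)c1)/C=C/c1ccc(O)c(OC)c1` differs from compound 3 by methoxymethyl in place of methoxy on a saturated chain carbon, two bonds along the chain from an amine nitrogen. For the measured compounds named here, no measured step bears readably on this change, and every measured analogue sits at a limit, so compound 4 is expected to show no step beyond the scatter, a number no higher from compound 3 to compound 4 (the limit leaves the size open). The estimate for compound 4 in this assay is 100000 nM, with a range of 50000 nM to 200000 nM, most likely reported again as a limit.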

Compound 4, half-maximal inhibitory concentration: > 100000 nM
Compound 4 gave a limit, no number; the forecaster's own chance of this, stated with the estimate: 85%; the middle value lies on the limit itself.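

Compound 4 stands at a limit in this assay, as do compound 1, compound 2 and compound 3, and none of the steps to compound 4 can be read. The compounds shown leave open how far any of these values lies beyond its limit, and whether any change on this chain would give a readable number.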